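The source may hold more compounds than are shown below. What is called first, only, known or untested is meant among the compounds shown, and "the series" means these compounds.

Working notes on the series.

Compound 1 `CCCC(C)Nc1nc(N)nc2cccnc12` carries a plain branched alkyl chain on the ring nitrogen; in an assay on tissue (PBMC cells) for agonist activity at Toll-like receptor 8 (Homo sapiens), with a stated time of 24 h (on this read-out higher numbers stand for an effect only at larger amounts of compound and lower numbers for an effect already at smaller amounts), compound 1 gives 3100 nM. Within the data shown here, compound 2 `CCCC[C@H](CN)Nc1nc(N)nc2cccnc12` bears an aminomethyl on the chain carbon attached to that nitrogen; in this assay compound 2 gives 25000 nM, the highest of the two numbers known so far, and its distance from compound 1 lies beyond the usual scatter.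

Compound 3 `CCCC[C@@H](Nc1nc(N)nc2cccnc12)C(=O)O` is the next member to be measured. The change from compound 2 is carboxy in place of aminomethyl on a saturated chain carbon bound to a nitrogen on an aromatic ring and a saturated chain carbon. Among the measured compounds shown here, no measured pair covers this kind of exchange, so the size of the step rests only on the pattern seen so far. A step of a 1.8-fold higher number from compound 2 to compound 3 (0.26 log units; within the scatter) is expected, toward a higher number or at most no change beyond the scatter, given that compound 2 already sits at 25000 nM. Compound 3 is therefore estimated at 45000 nM, with a range from 8000 nM to 250000 nM, and a real chance that only a limit is reported.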

Compound 3, half-maximal effective concentration: > 50000 nM
Compound 3: a limit, no number; the forecaster's own chance of this, stated with the estimate: 35%; middle value at least 1.1-fold (0.04 log units) away from the limit.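

In this assay compound 3 gives > 50000 nM, which is a limit of the assay and not a number. Carboxy in place of aminomethyl on this saturated chain carbon gives an at least 2.0-fold higher number from compound 2 to compound 3 (0.30 log units; that floor lies within the scatter), so the exchange yields no measurable half-maximal effective concentration, although the floor of the step does not by itself separate the two compounds. At this position, then, the series now holds one measured value with aminomethyl and one limit with carboxy, and the carboxy compound gives no sign of an effect at smaller amounts of compound than compound 2.

From the compounds shown here alone, how far compound 3 lies past its limit stays open, and with it the true size of the step. Also open, going by these compounds, is how a hydroxymethyl, an amide or a longer chain on this carbon would read in this assay.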